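Methoxy in Place of Hydrogen: an Expected Growth Inhibition Value

The source may report more compounds than this note shows. Statements on the series, on what has been measured and on what is new or still open speak of the compounds shown alone.

compound 1 `COc1cc(/C=C/C(=O)c2cccc(-n3cc(-c4ccccc4)[nH]c3=O)c2)ccc1O` 3850 nM
compound 2 `O=C(/C=C/c1cccc(O)c1)c1cccc(-n2cc(-c3ccccc3)[nH]c2=O)c1` 3890 nM
compound 3 `O=C(/C=C/c1cccc(O)c1)c1cccc(-n2cc(-c3ccc(Cl)cc3)[nH]c2=O)c1` 3550 nM

In a functional assay on A549 cells (Homo sapiens) for inhibition (a higher number here means a weaker inhibitor of growth, a lower number a stronger inhibitor of growth), compound 1 gives 3850 nM, compound 2 gives 3890 nM, and compound 3 gives 3550 nM. Compound 1 holds the second highest of these three numbers, yet the step of a 1.0-fold higher number from compound 1 to compound 2 (0.00 log units; within the scatter) lies within the scatter, and the values of compound 1 and compound 3 differ by less than the scatter as well.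

Compound 4 `COc1ccc(-c2cn(-c3cccc(C(=O)/C=C/c4ccc(O)c(OC)c4)c3)c(=O)[nH]2)cc1` differs from compound 1 by methoxy in place of hydrogen on an aromatic carbon, on the phenyl attached to the shared core. The step that bears on it most directly is a 1.1-fold lower number from compound 2 to compound 3 (0.04 log units; within the scatter), where another substituent replaced hydrogen on that same phenyl without moving the number beyond the scatter. On this basis compound 4 is expected to show a 1.0-fold lower number from compound 1 to compound 4 (0.01 log units; within the scatter), that is, no step beyond the scatter. The value of compound 4 in this assay is estimated at 3800 nM, within a range from 1900 nM to 7600 nM.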

Compound 4, concentration for 50% growth inhibition: 4140 nM
Compound 4: the middle estimate sits 1.1-fold (0.04 log units) below what was measured; measured number inside the range.
By their numbers in this assay, from the lowest: compounds 3, 1, 2 and 4 (each within the scatter of the next).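

In this assay, the change from phenyl to 4-methoxyphenyl gives a 1.1-fold higher number from compound 1 to compound 4 (0.03 log units; within the scatter). This ring has now taken a second group without a step beyond the scatter, after chloro in a 1.1-fold lower number from compound 2 to compound 3 (0.04 log units; within the scatter), and the new step stands on a different chain from that one, the one ending in 4-hydroxy-3-methoxyphenyl. Nothing available accounts for this absence of a step beyond the scatter. Going by these compounds, whether an amine or a carboxylic acid on this ring, or a butoxy chain in place of methoxy, would move the number beyond the scatter remains open.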